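The compounds below may be only part of what the source reports. "The series", "measured", "known", "first", "only" and "open" are said of these compounds alone.

For the measured compounds named here, in a functional assay on K562 cells (Homo sapiens) for antiproliferative activity, read by MTT assay, with a stated time of 24 h (a higher number here means a weaker inhibitor, a lower number a stronger inhibitor), compound 2 `COc1ccc(C(=O)/C=C/c2cccc(C(F)(F)F)c2)c2c1C=CC(C)(C)O2` gives 7850 nM, the only actual number so far. Compound 1 `COc1ccc(C(=O)/C=C/c2ccc(Br)cc2)c2c1C=CC(C)(C)O2` reads > 10000 nM in this assay, and this is a limit of the assay, not a number.

Next up is compound 3 `COc1ccc(C(=O)/C=C/c2cccc(Cl)c2)c2c1C=CC(C)(C)O2`, not yet measured in this assay. Its difference from compound 2 is chloro in place of trifluoromethyl on an aromatic carbon, meta to a large group.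

Going by the values given here, no pair of measured compounds differing in one place is available, so the series gives no step to calibrate against. The expectation is anchored on compound 2 at 7850 nM. The expected step, a 1.0-fold higher number from compound 2 to compound 3 (0.01 log units; within the scatter), is estimated to stay within the scatter, with no direction favoured. A reading reported only as a limit is also possible for compound 3, as happened with compound 1. For compound 3 the expected value is 8000 nM, with an estimated range from 4000 nM to 16000 nM.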

Compound 3, half-maximal inhibitory concentration: > 10000 nM
Compound 3: a limit, no number (the forecaster's own chance of this, stated with the estimate: 35%); middle value at least 1.2-fold (0.09 log units) from the limit.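

Chloro in place of trifluoromethyl on an aromatic carbon, meta to a large group, gives an at least 1.2-fold higher number from compound 2 to compound 3 (0.10 log units; that floor lies within the scatter) in this assay, so the first readable step at this position sets only a floor and does not show how far the change goes. Compound 3 reads > 10000 nM, which is a limit of the assay and not a number. The step between compound 1 and compound 3 cannot be read, because both readings are limits: the limit of > 10000 nM in this assay, at which 2 of the 3 values shown sit.

For the compounds shown here, still open is whether another kind of group at this place, such as an amine, a carboxylic acid or a methoxy group, would give a reading clearly different from compound 2 at 7850 nM, the only actual number. Also open, going by these compounds, is how far compound 1 and compound 3 lie beyond the limit, which the present readings cannot tell.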